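The source may hold more compounds than are shown below. What is called first, only, known or untested is meant among the compounds shown, and "the series" means these compounds.

Two compounds of this series have been run in a functional assay on A-431 cells (Homo sapiens) for inhibition, read by MTT assay, with a stated time of 72 h; a lower number here means a stronger inhibitor, a higher number a weaker inhibitor. Compound 1 `C/C=C/C(=O)Nc1cccc(Oc2nc(Nc3cccc(OC)c3)nc3ccsc23)c1` gives 13100 nM. Compound 2 `C=CC(=O)Nc1cccc(Oc2nc(Nc3cccc(C#N)c3)nc3ccsc23)c1` gives 3790 nM, the lowest of the two numbers; the number for compound 1 lies beyond the scatter above it, but these two differ in more than one place, so no single change can be read from them. Compound 3 `C/C=C/C(=O)Nc1cccc(Oc2nc(Nc3cccc(C#N)c3)nc3ccsc23)c1` is not yet measured and differs from compound 2 by prop-1-en-1-yl in place of vinyl on a carbonyl carbon. Within the data shown here, no measured pair isolates this change. The step of a 1.8-fold higher number from compound 2 to compound 3 (0.27 log units; within the scatter) is expected to be modest, toward a higher number, and may stay within the scatter. For compound 3 the estimate is 7000 nM, with a range from 2500 nM to 20000 nM.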

Compound 3, half-maximal inhibitory concentration: 20100 nM
Compound 3: middle estimate off by 2.9-fold (0.46 log units), on the low side; the measured number lies above the stated range.
By their numbers in this assay, from the lowest: compound 2; then compounds 1 and 3 (each within the scatter of the next).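

In this assay, among these compounds, the first single change that can be read at the carbonyl carbon is prop-1-en-1-yl in place of vinyl, which gives a 5.3-fold higher number from compound 2 to compound 3 (0.72 log units; beyond the scatter) with the rest of the molecule unchanged. With prop-1-en-1-yl held constant, cyano in place of methoxy on an aromatic carbon gives a 1.5-fold higher number from compound 1 to compound 3 (0.19 log units; within the scatter) in this assay. No supporting data bear on the cause of the vinyl step.

The compounds shown leave open whether the step holds with methoxy on the aromatic ring. They also leave open how an amine or a longer chain on the carbonyl carbon would read.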